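Cytotoxicity of a biaryl-substituted series on MT4 cells

A few compounds are considered here, and "the series" means these few. Any claim that something is new, unique, unknown or untested is made for them only; others in the source may bear on it.

Compound 1 `Cc1cc(C#N)cc(C)c1Oc1nc(Nc2ccc(C#N)cc2)ncc1-c1cccs1` — 6430 nM
Compound 2 `Cc1cc(C#N)cc(C)c1Oc1nc(Nc2ccc(C#N)cc2)ncc1-c1ccc(-c2ccccc2)cc1` — > 253000 nM
Compound 3 `Cc1cc(C#N)cc(C)c1Oc1nc(Nc2ccc(C#N)cc2)ncc1-c1ccc2ccccc2c1` — 8460 nM

Three compounds share a common core and differ only in the aryl group attached to an aromatic carbon of that core. In an ADME assay on MT4 cells (Homo sapiens) for cytotoxicity, read by MTT assay, with a stated time of 5 days (on this read-out lower numbers stand for higher toxicity in this test and higher numbers for lower toxicity in this test), compound 1 gives 6430 nM. For compound 2 the read-out is a limit of the assay, > 253000 nM, as noted in the limit of > 253000 nM in this assay, at which 1 of the 3 values shown sits. Compound 3 stands highest of the two numbers measured, with compound 1 its nearest neighbour: a 1.3-fold higher number from compound 1 to compound 3 (0.12 log units; within the scatter). Against the limit of compound 2 the step is large: an at least 29-fold lower number from compound 2 to compound 3 (1.47 log units; beyond the scatter), and so is an at least 39-fold higher number from compound 1 to compound 2 (1.59 log units; beyond the scatter).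

Compound 4 `Cc1ccc(-c2cnc(Nc3ccc(C#N)cc3)nc2Oc2c(C)cc(C#N)cc2C)cc1` is not yet measured. It differs from compound 3 in one place: 4-methylphenyl in place of naphthalen-2-yl on an aromatic carbon. Going by the values given here, of the measured steps, the one from compound 1 to compound 3 shows that swapping one bicyclic aromatic group for another leaves the number unchanged, while the step from compound 2 to compound 3 shows that 4-phenylphenyl sits far apart from the others. 4-methylphenyl is neither of these, so a modest upward shift in this assay is expected, possibly within the scatter. Compound 4 is estimated at 12000 nM, within 4000 nM to 60000 nM, meaning a 1.4-fold higher number from compound 3 to compound 4 (0.15 log units; within the scatter).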

Compound 4, half-maximal cytotoxic concentration: 26100 nM
Compound 4: the middle estimate sits 2.2-fold (0.34 log units) below what was measured, and the stated range covers the measured number.
By their numbers in this assay, from the lowest: compounds 1 and 3 (each within the scatter of the next); then compound 4. At a limit, above all of these: compound 2.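

In this assay, 4-methylphenyl stands apart from two groups whose numbers lie within the scatter of each other: a 3.1-fold higher number from compound 3 to compound 4 (0.49 log units; beyond the scatter), and a 4.1-fold higher number from compound 1 to compound 4 (0.61 log units; beyond the scatter). This position therefore gives more than one close pair and one far outlier, and the two compounds carrying a 4-substituted phenyl, compound 2 and compound 4, both stand above compound 1 and compound 3, with no listed compound going against this. Within that pair, methyl in place of phenyl still gives an at least 9.6-fold lower number from compound 2 to compound 4 (0.98 log units; beyond the scatter), but this step is only a bound, as compound 2 stands at a limit and not at a number: the limit of > 253000 nM in this assay, at which 1 of the 4 values shown sits.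

The compounds shown leave open where an unsubstituted phenyl would fall in this assay, and whether an amine or a carboxylic acid in place of the methyl of 4-methylphenyl would move the number up or down. They also leave open how far 4-phenylphenyl truly lies from 4-methylphenyl, since only a limit is available for that group.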